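Aryl substituent variation on the shared core, toward compound 4

This account rests on a few compounds, and the source may have more. Where it says the series, first, only, none or still open, it means among the compounds named here.

Measured compounds in a functional assay on HepG2 cells (Homo sapiens) for antiproliferative activity, read by MTT assay, with a stated time of 48 h; on this read-out lower numbers stand for stronger inhibition and higher numbers for weaker inhibition:
compound 1, `COc1ccc(CN2C(=O)C(=O)c3cc(-c4cc(OC)cc(OC)c4)ccc32)cc1`, gives 1200 nM
compound 2, `COc1ccc(CN2C(=O)C(=O)c3cc(-c4ccc(C(C)(C)C)cc4)ccc32)cc1`, gives 4580 nM
compound 3, `COc1ccc(CN2C(=O)C(=O)c3cc(-c4ccc(F)cc4)ccc32)cc1`, gives 3150 nM

Compound 3 holds the second highest of the three numbers; its nearest neighbour is compound 2, with a 1.5-fold lower number from compound 2 to compound 3 (0.16 log units; within the scatter), while compound 1 is furthest, with a 2.6-fold higher number from compound 1 to compound 3 (0.42 log units; beyond the scatter). Compound 4, `COc1ccc(CN2C(=O)C(=O)c3cc(-c4ccc(OC(C)C)cc4)ccc32)cc1`, has not yet been run in this assay. It differs from compound 3 in one place: isopropoxy in place of fluoro on an aromatic carbon.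

The step that bears most directly on this change is the exchange of the group on that same aromatic carbon, where the number moved from compound 2 to compound 3 only within the scatter. The two steps from compound 1, a 3.8-fold higher number from compound 1 to compound 2 (0.58 log units; beyond the scatter) and a 2.6-fold higher number from compound 1 to compound 3 (0.42 log units; beyond the scatter), concern a different substitution pattern and are both modest. On this evidence a swap of the group on that carbon gives no step beyond the scatter, and compound 4 is expected to sit close to compound 3, with a 1.2-fold lower number from compound 3 to compound 4 (0.08 log units; within the scatter). The estimate for compound 4 in this assay is 2600 nM, with a range from 1000 nM to 6500 nM.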

Compound 4, half-maximal inhibitory concentration: > 10000 nM
Compound 4: a limit, no number (the forecaster's own chance of this, stated with the estimate: 5%); middle value at least 3.8-fold (0.58 log units) away from the limit.
By their numbers in this assay, from the lowest: compound 1; then compounds 3 and 2 (each within the scatter of the next). At a limit, above all of these: compound 4.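

In this assay compound 4 stands as a limit and not a number: the limit of > 10000 nM in this assay, at which 1 of the 4 values shown sits.

The group on this aromatic carbon does matter: isopropoxy gives an at least 3.1-fold higher number from compound 3 to compound 4 (0.50 log units; beyond the scatter) and an at least 2.1-fold higher number from compound 2 to compound 4 (0.33 log units; beyond the scatter) while the exchange of tert-butyl for fluoro on the same carbon gave only a 1.5-fold lower number from compound 2 to compound 3 (0.16 log units; within the scatter) and so did not show this sensitivity. The change from 3,5-dimethoxyphenyl to 4-isopropoxyphenyl gives an at least 8.3-fold higher number from compound 1 to compound 4 (0.92 log units; beyond the scatter) and this exceeds both earlier steps away from 3,5-dimethoxyphenyl.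

Open, on these data alone, is whether the oxygen link or the branched chain goes with the loss, which a methoxy, a hydroxyl or an isopropyl group on that carbon would separate. Also open, as far as these compounds go, is whether an amine or a carboxylic acid there would stay near compound 3 or fall with compound 4.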